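This account rests on a few compounds, and the source may have more. Where it says the series, first, only, none or still open, it means among the compounds named here.

Measured compounds in a functional assay on the whole organism (strain albino) for inhibition, with Rattus norvegicus as the target, read by paw edema, with stated times of 1 h and 0.5 h, at a dose of 100 mg/kg by the oral route; on this read-out higher numbers stand for more inhibition at the one dose given (going by the name of the read-out) and lower numbers for less inhibition:
compound 1, `Cn1c(SCC(=O)Nn2c(COc3ccc(Cl)cc3Cl)nc3ccccc3c2=O)nc(-c2ccccc2)c(C#N)c1=O`: 51.9%
compound 2, `Cn1c(SCC(=O)Nn2c(COc3ccc(Cl)cc3Cl)nc3ccccc3c2=O)nc(-c2ccc(Cl)cc2)c(C#N)c1=O`: 80.8%
compound 3, `N#Cc1c(Nc2ccccc2)nc(SCC(=O)Nn2c(COc3ccc(Cl)cc3Cl)nc3ccccc3c2=O)nc1-c1ccc(O)cc1`: 90.4%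

Compound 1 and compound 2 share one core; compound 2 carries chloro in place of hydrogen on an aromatic carbon. That single change gives a number 28.9 percentage points higher from compound 1 to compound 2 (beyond the scatter). Compound 3 is built on a different core, and the difference between the two cores is not broken down here. In this assay compound 3 gives 90.4%, the highest of the three numbers, though its gap to compound 2 lies within the scatter, while its gap to compound 1 lies beyond it.

Compound 4, `N#Cc1c(Nc2ccc(Cl)cc2)nc(SCC(=O)Nn2c(COc3ccc(Cl)cc3Cl)nc3ccccc3c2=O)nc1-c1ccc(O)cc1`, has not yet been measured. It differs from compound 3 by chloro in place of hydrogen on an aromatic carbon, the same change that separates compound 2 from compound 1. Since compound 3 already stands near the top of the read-out, the step from compound 3 to compound 4 is expected to be smaller than the one already seen, about a number 3.6 percentage points higher from compound 3 to compound 4 (within the scatter). On that basis compound 4 is estimated at 94% in this assay, with an expected range from 84% to 99%; this rests on the rise in a number 28.9 percentage points higher from compound 1 to compound 2 (beyond the scatter) and on the value of compound 3.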

Compound 4, a percentage reported as inhibition, in the whole organism at one dose (the size of the read-out at that dose, not a potency): 65.4%
Beside the measured number, compound 4's estimate is 28.6 percentage points above it, and the stated range ends above it.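

In this assay, chloro in place of hydrogen on an aromatic carbon gives a number 25 percentage points lower from compound 3 to compound 4 (beyond the scatter). The step on one core therefore cannot be carried over to the other in this series, as the two steps run in opposite directions: the same change on two cores in this assay, a number 28.9 percentage points higher (beyond the scatter) from compound 1 to compound 2 and a number 25 percentage points lower (beyond the scatter) from compound 3 to compound 4, 53.9 percentage points apart, beyond the scatter of two such steps This does not show why they part, and two pairs set no rule for any further core; the chloro in compound 4 also stands on the anilino group, which compound 1 and compound 2 do not carry, so the comparison does not separate the core from the ring that takes the chloro.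

The compounds shown leave open whether fluoro, methyl or methoxy in place of the chloro would follow either step on these two cores. They also leave open whether a step of this kind would hold at doses other than the one given, or whether replacing the hydroxyl group of compound 3 and compound 4 with a methoxy group would alter it.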